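Chain at the ring carbon: compound 3 to compound 4

This account rests on a few compounds, and the source may have more. Where it says the series, first, only, none or still open, it means among the compounds named here.

Compound 1 `CCCc1ccncc1C#Cc1cc(Cl)ccc1OCC(=O)O`: 4.3 nM in an assay on CHO cells for displacement of a labelled ligand from prostaglandin D2 receptor 2 (Homo sapiens), read by scintillation counting; a higher number here means a weaker inhibitor, a lower number a stronger inhibitor
Compound 2 `O=C(O)COc1ccc(Cl)cc1C#Cc1cncc(S(=O)(=O)N2CCOCC2)c1`: 41 nM in this assay
Compound 3 `O=C(O)COc1ccc(Cl)cc1C#Cc1cccnc1`: 117 nM in this assay

Compound 3 carries the highest of the three numbers in this assay. The smaller gap below it is a 2.9-fold higher number from compound 2 to compound 3 (0.46 log units; beyond the scatter); the larger is a 27-fold higher number from compound 1 to compound 3 (1.43 log units; beyond the scatter). Both changes remove a group from compound 3's core; neither lies within the scatter.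

Compound 4 `CCCCCCc1ccncc1C#Cc1cc(Cl)ccc1OCC(=O)O` differs from compound 3 by hexyl in place of hydrogen on an aromatic carbon, on an aromatic carbon of a six-membered aromatic ring with 1 nitrogen, ortho to a large group, opposite the ring nitrogen. Of the two measured steps, a 27-fold higher number from compound 1 to compound 3 (1.43 log units; beyond the scatter) concerns this very carbon and is the one that bears on the change: there, a propyl chain in place of hydrogen accompanied a large drop in the number. The step of a 2.9-fold higher number from compound 2 to compound 3 (0.46 log units; beyond the scatter) touches a different position and a different kind of group, and says little here. Among the compounds with values here, a hexyl chain is longer than propyl, and no measured compound shows how far the chain can grow, so the expectation rests on compound 1 alone. In this assay compound 4 is therefore expected to give 6 nM, within 1.5 nM to 25 nM, a step of a 20-fold lower number from compound 3 to compound 4 (1.29 log units; beyond the scatter).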

Compound 4, inhibition constant: 43 nM
Estimate against measurement, compound 4: 7.2-fold (0.86 log units) below, outside the stated range (above it).
By their numbers in this assay, from the lowest: compound 1; then compounds 2 and 4 (each within the scatter of the next); then compound 3.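

In this assay a hexyl chain at this carbon still lowers the number relative to hydrogen, a 2.7-fold lower number from compound 3 to compound 4 (0.43 log units; beyond the scatter), but extending the chain beyond propyl loses much of the gain seen with compound 1, a 10-fold higher number from compound 1 to compound 4 (1.00 log units; beyond the scatter). Among hydrogen, propyl and hexyl at this carbon, opposite the ring nitrogen, the number is lowest with propyl, so it does not fall steadily with chain length across these three compounds. Nothing available explains the reversal between propyl and hexyl.

The compounds shown leave open where between propyl and hexyl the number starts to rise, which butyl and pentyl chains would help to place, and whether ethyl would do as well as propyl. Also open, from the compounds shown here alone, is how a branched chain such as isopropyl, or a propyl chain ending in an amine or a hydroxyl, would behave at this carbon.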